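The compounds below may be only part of what the source reports. "The series", "measured", "known", "first", "only" and "open" are said of these compounds alone.

Among the compounds with values here, compound 1, `CCCc1nc(CC)c(C(=O)OCCC[S+]([O-])c2ccccc2)n1Cc1ccc(-c2ccccc2S(=O)(=O)NC(=O)OCCC(C)C)cc1F`, is the stronger of the two compounds measured so far. In an assay on isolated protein for binding affinity to Type-2 angiotensin II receptor (Homo sapiens) (on this read-out lower numbers stand for stronger inhibition and higher numbers for weaker inhibition), compound 1 gives 1 nM, the lowest of the two numbers. Compound 2, `CCCc1nc(CC)c(C(=O)OCc2ccccc2-c2ccccc2)n1Cc1ccc(-c2ccccc2-c2nn[nH]n2)cc1`, differs from it in several places at once; in this assay compound 2 gives 2000 nM, a far higher number, well beyond the usual scatter. Within the data shown here, no single-point step between these two can be read off, so the gap shows only that compound 1 binds much more tightly than compound 2.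

Compound 3, `CCCc1nc(CC)c(C(=O)OCc2ccccc2OC)n1Cc1ccc(-c2ccccc2S(=O)(=O)NC(=O)OCCC(C)C)cc1F`, has not yet been measured. It differs from compound 1 in one place: a group of 8 heavy atoms (7 carbon, 1 oxygen; one six-membered aromatic ring of carbon only) in place of a group of 10 heavy atoms (8 carbon, 1 oxygen, 1 sulfur; one six-membered aromatic ring of carbon only), on a saturated chain carbon bound to an oxygen next to a carbonyl group. Everything else in compound 1 is kept. Among the measured compounds shown here, no measured pair shows what this particular exchange does, so the expectation rests on the remainder of compound 1 staying the same, including the part that compound 2 lacks. A small weakening is expected, a 3.0-fold higher number from compound 1 to compound 3 (0.48 log units; beyond the scatter), a step that may not exceed the scatter. Compound 3 is therefore estimated at 3 nM in this assay, with a range from 0.7 nM to 15 nM.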

Compound 3, half-maximal inhibitory concentration: 1 nM
Beside the measured number, compound 3's estimate is 3.0-fold (0.48 log units) above it; measured number inside the range.
By their numbers in this assay, from the lowest: compounds 1 and 3 (each within the scatter of the next); then compound 2.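

In this assay, putting 2-methoxyphenyl in place of the sulfur-containing group of 10 heavy atoms, on a saturated chain carbon bound to an oxygen next to a carbonyl group, gives no change at the digits printed from compound 1 to compound 3 (within the scatter). Within the data shown here, this is the first single-place comparison, and it shows that this position can hold either group while the rest of compound 1 stays the same, with no difference that can be told from the scatter. The two groups share one six-membered aromatic ring of carbon only and one hydrogen-bond acceptor, while the sulfur atom is present only in the group from compound 1, so in this pair sulfur is not needed for a number this low. No measurement available here explains why the two groups give matching results.

The compounds shown leave open whether this position would still tolerate a group without an aromatic ring, such as a plain ethyl chain or a simple amine. Compound 2 still differs from both compound 1 and compound 3 in several places, so no single change can yet be tied to its much higher number.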